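A few compounds are considered here, and "the series" means these few. Any claim that something is new, unique, unknown or untested is made for them only; others in the source may bear on it.

The series starts from compound 2, `Cc1c(OCCCCOc2ccc(C(=O)O)cc2)ccc(C(=O)CC(C)C)c1O`, which in an assay on HEK293 cells for positive allosteric modulation of metabotropic glutamate receptor 2 (Rattus norvegicus), read by thallium flux, with a stated time of 2.5 min (on this read-out lower numbers stand for an effect already at smaller amounts and higher numbers for an effect only at larger amounts of compound), gives 122 nM. Two single changes lead away from it. Compound 1, `Cc1c(OCCCCOc2ccc(C(=O)O)cc2)ccc(C(=O)CC2CCCC2)c1O`, carries cyclopentyl in place of isopropyl on a saturated chain carbon bound to a carbonyl carbon and in this assay gives 824 nM, a step of a 6.8-fold higher number from compound 2 to compound 1 (0.83 log units; beyond the scatter). Compound 3, `Cc1ccc(C(=O)O)cc1OCCCCOc1ccc(C(=O)CC(C)C)c(O)c1C`, keeps the isobutylcarbonyl but carries 5-carboxy-2-methylphenyl in place of 4-carboxyphenyl on an oxygen on a saturated carbon; in this assay compound 3 gives 454 nM, a step of a 3.7-fold higher number from compound 2 to compound 3 (0.57 log units; beyond the scatter). Compound 1 and compound 3 lie within the usual scatter of each other.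

Compound 4, `Cc1ccc(C(=O)O)cc1OCCCCOc1ccc(C(=O)CC2CCCC2)c(O)c1C`, has not been measured. It differs from compound 3 by cyclopentyl in place of isopropyl on a saturated chain carbon bound to a carbonyl carbon, at a place described in the same words as for the change from compound 2 to compound 1, so it is the same change, applied here on the core of compound 3 instead of the core of compound 2. Among the compounds with values here, the only measured instance of this change is the step from compound 2 to compound 1, which in this assay raised the number by a 6.8-fold higher number from compound 2 to compound 1 (0.83 log units; beyond the scatter). Because compound 3 already gives 454 nM, compound 4 is expected to show a step of a 6.2-fold higher number from compound 3 to compound 4 (0.79 log units; beyond the scatter), of similar size to the earlier one, though resting on a single precedent. Compound 4 is therefore estimated at 2800 nM, between 1100 nM and 7500 nM.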

Compound 4, half-maximal effective concentration: 1290 nM
The estimate for compound 4 lay 2.2-fold (0.34 log units) above the measured number; measured number inside the range.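

On the core of compound 3, cyclopentyl in place of isopropyl gives a 2.8-fold higher number from compound 3 to compound 4 (0.45 log units; beyond the scatter) in this assay, a rise in the same direction as on the core of compound 2, and the two steps cannot be told apart: the same change on two cores in this assay, a 6.8-fold higher number (0.83 log units; beyond the scatter) from compound 2 to compound 1 and a 2.8-fold higher number (0.45 log units; beyond the scatter) from compound 3 to compound 4, 2.4-fold (0.38 log units) apart, within the scatter of two such steps. The change from 4-carboxyphenyl to 5-carboxy-2-methylphenyl, read on the cyclopentyl compounds, gives a 1.6-fold higher number from compound 1 to compound 4 (0.19 log units; within the scatter), and this smaller step also cannot be told apart from its counterpart on the isopropyl compounds: the same change on two cores in this assay, a 3.7-fold higher number (0.57 log units; beyond the scatter) from compound 2 to compound 3 and a 1.6-fold higher number (0.19 log units; within the scatter) from compound 1 to compound 4, 2.4-fold (0.38 log units) apart, within the scatter of two such steps. Across these four compounds, neither change shows a size that depends on the core, but this does not prove that the sizes are equal, as each comparison rests on a single pair of steps and says nothing about other cores.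

The compounds shown leave open how cyclohexyl or a tert-butyl group would behave on the saturated chain carbon bound to the carbonyl carbon. They also leave open what a tetrazole or an amide in place of the carboxylic acid, or a longer linking chain, would do to these steps.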